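The compounds below may be only part of what the source reports. "The series", "measured", "known", "first", "only" and "open" are said of these compounds alone.

Compound 1 `FC(F)(F)c1cccc(-c2nc3cnc(Nc4ccncn4)cc3[nH]2)c1`: 200000 nM
Compound 2 `O=C(O)c1ccnc(Nc2cc3[nH]c(-c4cccc(C(F)(F)F)c4)nc3cn2)c1`: < 5000 nM

Compound 2 stands at the low end of what has been measured. In a physicochemical assay for solubility, using the shake flask method, measured as kinetic solubility, with a stated time of 20 h, at pH 2 (on this read-out lower numbers stand for lower solubility and higher numbers for higher solubility), compound 2 gives only a limit, < 5000 nM, which is a limit of the assay rather than a number (the limit of < 5000 nM in this assay, at which 1 of the 2 values shown sits). Compound 3 `NC(=O)c1ccc(Nc2cc3[nH]c(-c4cccc(C(F)(F)F)c4)nc3cn2)nc1` is not yet measured and differs from compound 2 in one place: 5-carbamoylpyridin-2-yl in place of 4-carboxypyridin-2-yl on a nitrogen on an aromatic ring. For the measured compounds named here, the only measured step, an at least 40-fold lower number from compound 1 to compound 2 (1.60 log units; beyond the scatter), swaps a different group at the same nitrogen and so bears only loosely on this change. Compound 3 is expected to move upward, by an uncertain amount: an at least 4.0-fold higher number from compound 2 to compound 3 (0.60 log units; beyond the scatter). The estimate for compound 3 is 20000 nM, ranging from 3000 nM to 150000 nM.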

Compound 3, solubility: < 5000 nM
Compound 3 was reported as a limit (the forecaster's own chance of this, stated with the estimate: 30%); at least 4.0-fold (0.60 log units) between middle value and limit.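

In this assay compound 3 also gives a limit of the assay, < 5000 nM, and not a number. The new group, 5-carbamoylpyridin-2-yl, gives an at least 40-fold lower number from compound 1 to compound 3 (1.60 log units; beyond the scatter), so a second group at this nitrogen lands far from pyrimidin-4-yl. The step between compound 2 and compound 3 cannot be read, as both values sit at the same limit: the limit of < 5000 nM in this assay, at which 2 of the 3 values shown sit.

On these data alone, how far compound 2 and compound 3 lie under that limit remains open. So does whether an amine on the pyridin-2-yl ring would give a readable number.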